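A few compounds are considered here, and "the series" means these few. Any claim that something is new, unique, unknown or untested is made for them only; others in the source may bear on it.

Measured so far:
- Compound 1, `Cn1c(C(F)(F)F)ccc(NCc2cc3cc(Cl)ccc3[nH]c2=O)c1=O`, gives 85% in an ADME assay on microsomes from liver (Homo sapiens) for metabolic stability, with a stated time of 30 min; a higher number here means that more of the compound is left, a lower number that less of the compound is left.
- Compound 2, `COc1cccc(NCc2cc3cc(Cl)ccc3[nH]c2=O)c1`, gives 78% in this assay.
- Compound 3, `C[C@H](Nc1ccc(C#N)n(C)c1=O)c1cc2cc(Cl)c(O[C@H](C)c3ccccn3)cc2[nH]c1=O`, gives 70% in this assay.

Compound 3 sits at the low end of the three values. Its distance to compound 2 lies within the scatter of repeated measurements, so the two cannot be ranked against each other; only its distance to compound 1 lies beyond the scatter. Going by the values given here, no pair among the measured compounds differs in a single place, so no measured step is available to lean on.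

Compound 4, `C[C@H](Nc1ccc(C#N)n(C)c1=O)c1cc2cc(Cl)c(OCc3ccccn3)cc2[nH]c1=O`, differs from compound 3 by hydrogen in place of methyl on a saturated chain carbon bound to an aromatic carbon and an oxygen on an aromatic ring. The change is small in count and leaves the rest of the structure untouched. Among the compounds with values here, with no measured step of this kind to compare, the step of a number 2 percentage points lower from compound 3 to compound 4 (within the scatter) is expected to be small, in no particular direction, and is estimated to stay within the scatter. For compound 4 the value in this assay is therefore estimated at 68%, with a range from 50% to 85%.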

Compound 4, percent of the compound remaining: 66%
For compound 4 the middle estimate is 2 percentage points above the measured one; the measured number falls inside the stated range.
By their numbers in this assay, from the lowest: compounds 4, 3, 2 and 1 (each within the scatter of the next, the first and the last beyond it).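

In this assay, going by these compounds alone, the exchange of 1-(pyridin-2-yl)ethoxy for (pyridin-2-yl)methoxy gives the first step that can be read at a single place: a number 4 percentage points lower from compound 3 to compound 4 (within the scatter). On this saturated chain carbon, then, hydrogen in place of methyl leaves the percent of compound remaining indistinguishable, and the two compounds cannot be ranked against each other. No measurement at hand bears on why the step is this size.

The compounds shown leave open how an ethyl, a hydroxymethyl or a dimethylamino group on this same carbon would read in this assay. They also leave open whether hydrogen in place of methyl gives a step of similar size in another part of the structure, since a single pair carries the whole reading.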